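Phenyl to cyclopropyl on the side chain of compound 2

The source may report more compounds than this note shows. Statements on the series, on what has been measured and on what is new or still open speak of the compounds shown alone.

Measured in a functional assay on a cell-free system (plasma, Homo sapiens), with a stated time of 3 min (a higher number here means a weaker inhibitor, a lower number a stronger inhibitor), as follows
- compound 1 `CC(C)(C)C[C@@H](O)C(=O)N1[C@@H]2C[C@@H]2C[C@H]1C(=O)NCc1cc(Cl)ccc1-n1cnnn1` gives 520 nM
- compound 2 `O=C(NCc1cc(Cl)ccc1-n1cnnn1)[C@@H]1[C@H]2C[C@H]2CN1C(=O)[C@H](O)Cc1ccccc1` gives 1200 nM
- compound 3 `O=C(NCc1cc(Cl)ccc1-n1cnnn1)[C@@H]1[C@@H]2C[C@@H]2CN1C(=O)[C@H](O)Cc1ccccc1` gives 970 nM

In this assay compound 2 stands at 1200 nM and lies within the scatter of compound 3, while its number is higher than that of compound 1 by more than the scatter.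

Compound 4 `O=C(NCc1cc(Cl)ccc1-n1cnnn1)[C@@H]1[C@H]2C[C@H]2CN1C(=O)[C@H](O)CC1CC1` differs from compound 2 by cyclopropyl in place of phenyl on a saturated chain carbon, two bonds along the chain from a carbonyl carbon and an oxygen on a saturated carbon with cyclopropyl in place of phenyl on a saturated chain carbon, two bonds along the chain from a carbonyl carbon and an oxygen on a saturated carbon; cut one bond further out, this reads benzyl to cyclopropylmethyl.

Among the compounds with values here, the only measured step is a 1.2-fold lower number from compound 2 to compound 3 (0.09 log units; within the scatter) and it concerns the fact that compounds 2 and 3 differ only in the configuration as drawn so it gives no direct size for this exchange. Compound 1 also carries no phenyl, but its core differs too, so its 520 nM is no clean guide. From the compounds shown here alone, no step beyond the scatter is therefore expected, and the direction stays open.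

The expected step is a 1.2-fold higher number from compound 2 to compound 4 (0.07 log units; within the scatter) and it remains an estimate.

For compound 4 the estimated value is 1400 nM with an expected range from 500 nM to 4000 nM in this measurement.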

Compound 4, half-maximal inhibitory concentration: 1400 nM
Compound 4: the middle estimate sits on the measured number at the digits printed; the range from low to high includes it.
By their numbers in this assay, from the lowest: compounds 1, 3, 2 and 4 (each within the scatter of the next, the first and the last beyond it).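

In this assay the exchange of phenyl for cyclopropyl on the saturated chain carbon gives a 1.2-fold higher number from compound 2 to compound 4 (0.07 log units; within the scatter) and so stays within the scatter. Within the data shown here, the earlier step concerned configuration only, whereas this one is the first reading at the side chain: going from 6 heavy atoms to 3, and from a six-membered aromatic ring to a three-membered non-aromatic ring, leaves no difference that can be told from the scatter. Nothing shown gives a cause for this result.

From the compounds shown here alone, whether an amine, a carboxylic acid or a longer chain on this carbon would give a step beyond the scatter stays open. Also open, going by these compounds, is how the side chain of compound 1 would read on the core of compound 2.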